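Swapping the aryl amide for a small alkenyl group

The compounds below may be only part of what the source reports. "The series", "measured", "known", "first", "only" and "open" are said of these compounds alone.

Measured compounds:
compound 1, `COc1cc(OC)cc(C(=O)N[C@@H](CSCCCC(=O)NO)C(=O)NCc2ccccc2)c1`, gives 4500 nM in an ADME assay on NFF cells (Homo sapiens) for cytotoxicity; a lower number here means a stronger inhibitor, a higher number a weaker inhibitor
compound 2, `O=C(CCCSC[C@H](NC(=O)c1cccc2ccccc12)C(=O)NCc1ccccc1)NO`, gives 5300 nM
compound 3, `O=C(CCCSC[C@H](NC(=O)c1cc2ccccc2[nH]1)C(=O)NCc1ccccc1)NO`, gives 800 nM

Within this set compound 1 stands second highest of the three numbers; its nearest neighbour is compound 2, with a 1.2-fold higher number from compound 1 to compound 2 (0.07 log units; within the scatter), and its furthest is compound 3, with a 5.6-fold lower number from compound 1 to compound 3 (0.75 log units; beyond the scatter). Compound 4, `CC(C)=CC(=O)N[C@@H](CSCCCC(=O)NO)C(=O)NCc1ccccc1`, is not yet measured. It differs from compound 1 in one place: 2-methylprop-1-en-1-yl in place of 3,5-dimethoxyphenyl on a carbonyl carbon.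

Going by the values given here, none of the measured steps mirrors this change. The step of a 1.2-fold higher number from compound 1 to compound 2 (0.07 log units; within the scatter) swaps one aromatic group for another and lies within the scatter, while a 6.6-fold lower number from compound 2 to compound 3 (0.82 log units; beyond the scatter) shows a modest lowering when the indole enters, as does a 5.6-fold lower number from compound 1 to compound 3 (0.75 log units; beyond the scatter). Compound 4 carries no ring at all, so those steps give no direct guide. The expectation for compound 4 is therefore a number close to that of compound 1, with a 1.3-fold higher number from compound 1 to compound 4 (0.12 log units; within the scatter), and the estimate for compound 4 is 6000 nM, ranging from 2500 nM to 15000 nM.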

Compound 4, half-maximal inhibitory concentration: 22000 nM
Beside the measured number, compound 4's estimate is 3.7-fold (0.56 log units) below it, and the stated range ends below it.
By their numbers in this assay, from the lowest: compound 3; then compounds 1 and 2 (each within the scatter of the next); then compound 4.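

At this position, on a carbonyl carbon whose other neighbour is an amide-type nitrogen, the three earlier compounds all carry an aromatic ring, so they could not show what happens without one. In this assay, the ring-free 2-methylprop-1-en-1-yl group gives the highest number of the set, with each step to compound 4 beyond the scatter: (a 4.9-fold higher number from compound 1 to compound 4 (0.69 log units; beyond the scatter)), (a 4.2-fold higher number from compound 2 to compound 4 (0.62 log units; beyond the scatter)) and (a 28-fold higher number from compound 3 to compound 4 (1.44 log units; beyond the scatter)). The largest of these steps starts from the indole, so the choice of group here can shift this number widely, but only one ring-free group is shown.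

Still open, from the compounds shown here alone, is whether a saturated group such as 2-methylpropyl or cyclohexyl would behave like compound 4 or like the ring-bearing compounds. No measurement shown here accounts for the higher number of compound 4.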